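Furan for thiophene on an aryl amine: antiproliferative notes

The source may report more compounds than this note shows. Statements on the series, on what has been measured and on what is new or still open speak of the compounds shown alone.

Measured compounds and values:
compound 1, `N#Cc1ccc(N2CCc3cc(-c4cnc5ccccc5c4)ccc3C2)cc1C(F)(F)F`, 25100 nM
compound 2, `CCN(c1ccc(C#N)c(Cl)c1)c1cc(-c2cccs2)ccc1C`, > 30000 nM
compound 3, `N#Cc1ccc(N2CCCc3c(-c4ccncc4)cccc32)cc1C(F)(F)F`, 28700 nM

In a functional assay on PC-3 cells (Homo sapiens) for antiproliferative activity, read by CCK-8 assay, with a stated time of 6 days (a lower number here means a stronger inhibitor, a higher number a weaker inhibitor), compound 1 gives 25100 nM. Compound 3 gives 28700 nM in this assay, a value within the usual scatter of that of compound 1, so no order between the two is claimed. Compound 2 returns only a limit in this assay, > 30000 nM; this is the assay's reporting limit, not a number, as recorded in the limit of > 30000 nM in this assay, at which 1 of the 3 values shown sits. Compound 2 therefore stands at the weak end of what is shown, with no measured potency of its own.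

Compound 4, `CCN(c1ccc(C#N)c(Cl)c1)c1cc(-c2ccco2)ccc1C`, has not been measured in this assay. It differs from compound 2 in one place: furan-2-yl in place of thiophen-2-yl on an aromatic carbon. Among the compounds with values here, no step between measured compounds is available for this change, so the size of the step can only be expected, not read from the data. Given that compound 2 gives > 30000 nM, a step from compound 2 to compound 4 of about a step that the limit leaves unreadable from compound 2 to compound 4 is expected, which is no change beyond the scatter. Compound 4 is thus expected to give about 35000 nM in this assay, in the range 15000 nM to 80000 nM, most likely again as a limit.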

Compound 4, half-maximal inhibitory concentration: > 30000 nM
Compound 4: only a limit was reported; the forecaster's own chance of this, stated with the estimate: 70%; the middle value lies beyond the limit too.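

Compound 2 and compound 4 both return only a limit in this assay, so the step for furan-2-yl in place of thiophen-2-yl cannot be read; both sit at the same reporting limit: the limit of > 30000 nM in this assay, at which 2 of the 4 values shown sit.

The compounds shown leave open how far apart compound 2 and compound 4 lie, and whether either has a measurable potency in this assay.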